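The source may hold more compounds than are shown below. What is called first, only, known or untested is meant among the compounds shown, and "the series" means these compounds.

Compound 1 `COc1cc(OC)cc(C(=O)Nc2ccc(Nc3nc(C)cc(N(C)C)n3)cc2)c1`, compound 2 `COc1cccc(Nc2nc(C)cc(N(C)C)n2)c1` and compound 3 `Cc1cc(N(C)C)nc(NCc2ccccc2)n1` share a common core and have all been tested in a physicochemical assay for solubility, read by nephelometry, measured as kinetic solubility; a lower number here means a less soluble compound, a higher number a more soluble compound. In this assay compound 1 gives 20000 nM. For compound 2 this assay reports only a limit, > 250000 nM, and not a number. Compound 3 likewise reaches only a limit in this assay, > 250000 nM. The reading of compound 3 therefore sits at the limit of > 250000 nM in this assay, at which 2 of the 3 values shown sit, which is the highest point this assay reports. Compound 4 `Cc1cc(N(C)C)nc(N[C@H](C)c2ccccc2)n1` has not yet been measured. It differs from compound 3 by methyl in place of hydrogen on a saturated chain carbon bound to an aromatic carbon and a nitrogen on an aromatic ring. Within the data shown here, no pair of measured compounds shows what this particular change does in this assay, so the expectation for compound 4 rests only on where compound 3 stands. With compound 3 already at the limit, the step from compound 3 to compound 4 is expected to be a number no higher from compound 3 to compound 4 (the limit leaves the size open), that is, nothing beyond the usual scatter and in no particular direction. Compound 4 is accordingly expected to give 250000 nM in this assay, with a range from 80000 nM to 250000 nM, and most likely the measurement will again stop at a limit rather than a number.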

Compound 4, solubility: > 250000 nM
Compound 4 gave a limit, no number; the forecaster's own chance of this, stated with the estimate: 70%; the middle value lies on the limit itself.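

In this assay, among these compounds, compound 3 and compound 4 both stop at a limit rather than a number, so no step between them can be read: the limit of > 250000 nM in this assay, at which 3 of the 4 values shown sit. The compounds shown leave open how far the true solubility of compound 3 and compound 4 lies past that limit, and whether methyl in place of hydrogen changes it at all.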